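This account rests on a few compounds, and the source may have more. Where it says the series, first, only, none or still open, it means among the compounds named here.

The account concerns a series of nucleoside analogues tested in a functional assay on NCI-H23 cells (Homo sapiens) for cytotoxicity, read by sulforhodamine B assay, tested at 10 uM; a higher number here means more inhibition at the concentration tested (going by the name of the read-out), a lower number less inhibition. Compound 1, `CC(C)(C)c1ccc(Cn2cc(-c3cn([C@H]4C[C@H](O)[C@@H](CO)O4)c(=O)[nH]c3=O)nn2)cc1`, gives 95% in this assay. Compound 3, `CC(=O)OC[C@H]1O[C@@H](n2cc(-c3cn(Cc4ccc(C(C)(C)C)cc4)nn3)c(=O)[nH]c2=O)C[C@@H]1OC(C)=O`, gives 106%. Compound 2, `CCCCCCCCc1cc(-c2cn([C@H]3C[C@H](O)[C@@H](CO)O3)c(=O)[nH]c2=O)on1`, gives 120%, the highest of the three numbers; its nearest neighbour is compound 3, whose number lies beyond the scatter below it, and its furthest is compound 1, whose number lies further below, also beyond the scatter.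

The step under consideration leads from compound 2 to compound 4, `CC(C)(C)c1ccc(-c2cc(-c3cn([C@H]4C[C@H](O)[C@@H](CO)O4)c(=O)[nH]c3=O)on2)cc1`. The change is 4-(tert-butyl)phenyl in place of octyl on an aromatic carbon. Going by the values given here, no measured pair shows this change directly. Compounds 1 and 3 already carry a 4-(tert-butyl)phenyl fragment within a benzyl group on a different five-membered ring, and both reach high inhibition, yet below compound 2. The step from compound 2 to compound 4 is therefore expected to be small and, if anything, downward, estimated at a number 15 percentage points lower from compound 2 to compound 4 (beyond the scatter). Compound 4 is expected to give about 105% in this assay, within a range from 85% to 125%.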

Compound 4, a percentage reported as inhibition, at one concentration (the size of the read-out at that concentration, not a potency): 98.9%
For compound 4 the middle estimate is 6.1 percentage points above the measured one; low and high end bracket the measured number.
By their numbers in this assay, from the lowest: compounds 1, 4 and 3 (each within the scatter of the next, the first and the last beyond it); then compound 2.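

In this assay, going by these compounds alone, replacing octyl with 4-(tert-butyl)phenyl on this aromatic carbon next to the ring nitrogen gives a number 21.1 percentage points lower from compound 2 to compound 4 (beyond the scatter), the first direct evidence that the group at this position affects the read-out. The position accepts a six-membered aromatic ring without losing the effect, as compound 4 still gives 98.9%. Nothing available bears on why the number falls with this change.

The compounds shown leave open whether a shorter chain, an unsubstituted phenyl or an amine on this carbon would stay nearer to compound 2 or to compound 4. They also leave open whether the step would keep its size with a hexyl chain in place of octyl, and how these numbers at one concentration relate to potency.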